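Shifting a methyl on the pendant phenyl of compound 1

The source may report more compounds than this note shows. Statements on the series, on what has been measured and on what is new or still open speak of the compounds shown alone.

Among the measured compounds shown here, compound 1 `Cc1cccc(-c2cc(Cl)cc(Cl)c2/C=C/[C@@H]2C[C@@H](O)CC(=O)O2)c1` is one of three compounds measured in an assay for inhibition of 3-hydroxy-3-methylglutaryl-coenzyme A reductase (Rattus norvegicus) (on this read-out higher numbers stand for weaker inhibition and lower numbers for stronger inhibition), where compound 1 gives 16 nM. Among the three numbers this is the second highest. The nearest to it belongs to compound 3 `Cc1cc(C)c(/C=C/[C@@H]2C[C@@H](O)CC(=O)O2)c(-c2ccc(F)cc2)c1`, which in this assay gives 13 nM; the two lie within the usual scatter of each other, so nothing separates them. The furthest belongs to compound 2 `O=C1C[C@H](O)C[C@@H](/C=C/c2ccccc2-c2ccccc2)O1`, which in this assay gives 3000 nM, a gap that lies well beyond the scatter.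

Compound 4 `Cc1ccccc1-c1cc(Cl)cc(Cl)c1/C=C/[C@@H]1C[C@@H](O)CC(=O)O1` has not yet been measured in this assay. It shares every atom with compound 1, joined differently: 2-methylphenyl in place of 3-methylphenyl on an aromatic carbon. The core of compound 1 and its two chloro groups stay as they are; only the position of the methyl on the pendant phenyl moves.

For the measured compounds named here, no step between two measured compounds mirrors this change, so there is no directly comparable precedent. Compounds 1 and 3 both carry a substituted pendant phenyl and both sit at strong inhibition, whereas compound 2, with no substituent there, sits far weaker. On that basis the step from compound 1 to compound 4 is expected to be modest, a 1.6-fold higher number from compound 1 to compound 4 (0.19 log units; within the scatter), with no direction claimed beyond the scatter. For compound 4 in this assay the estimate is 25 nM, spanning 8 nM to 80 nM.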

Compound 4, half-maximal inhibitory concentration: 370 nM
Compound 4: middle estimate off by 15-fold (1.17 log units), on the low side; measured number outside the range, above it.
By their numbers in this assay, from the lowest: compounds 3 and 1 (each within the scatter of the next); then compound 4; then compound 2.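

In this assay the move of one methyl from 3-methylphenyl to 2-methylphenyl gives a 23-fold higher number from compound 1 to compound 4 (1.36 log units; beyond the scatter) and so shows that inhibition is sensitive to where the methyl sits on the pendant phenyl, even though the group that leaves and the group that enters have the same atoms and the same counts. The earlier compounds shown here could not show this, as no two of them differed in one place, and the strong numbers of compound 1 and compound 3 gave no view of how a single substituent's position on that ring behaves; here the position alone separates two compounds by far more than the scatter. Nothing shown here gives a measured explanation for this step.

On these data alone, what remains open is whether the weaker inhibition of compound 4 belongs to the methyl in particular or would follow any group at that place, which a methoxy group, a chloro group or a hydroxyl group in place of that methyl would begin to test. Also open, as far as these compounds go, is how a plain phenyl on the core of compound 1 would stand against both methylphenyl compounds, and so whether the methyl of compound 1 itself adds anything.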